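A few compounds are considered here, and "the series" means these few. Any claim that something is new, unique, unknown or untested is made for them only; others in the source may bear on it.

Compound 1 `Cc1ccc(S(=O)(=O)N(Cc2ccccc2)Cc2cccc(F)c2F)cc1` gives -35.7% in a functional assay on 3T3-L1 cells (Mus musculus) for inhibition, with a stated time of 20 min, tested at 20 uM; a lower number here means less inhibition, a higher number more inhibition at the concentration tested (going by the name of the read-out).
Compound 2 `Cc1ccc(S(=O)(=O)N(Cc2cn(Cc3ccccc3Cl)nn2)Cc2cn(S(=O)(=O)c3ccc(C)cc3)c3ccccc23)cc1` gives -4.8% in this assay.
Compound 3 `COc1ccc(Cn2cc(CN(Cc3cn(S(=O)(=O)c4ccc(C)cc4)c4ccccc34)S(=O)(=O)c3ccc(C)cc3)nn2)cc1` gives 1% in this assay.

Compound 3 lies beyond the scatter above compound 1 and within the scatter of compound 2; its reading is close to zero, so neither compound 2 nor compound 3 shows inhibition worth the name at the concentration tested. Going by the values given here, the one step on record in this part of the structure, a number 5.8 percentage points higher from compound 2 to compound 3 (within the scatter), swaps the aryl group on the saturated chain carbon bound to the aromatic nitrogen and moves the read-out only within the scatter.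

Compound 4 `Cc1ccc(S(=O)(=O)N(Cc2cn(Cc3ccc(F)cc3F)nn2)Cc2cn(S(=O)(=O)c3ccc(C)cc3)c3ccccc23)cc1` differs from compound 3 by 2,4-difluorophenyl in place of 4-methoxyphenyl on a saturated chain carbon bound to an aromatic nitrogen. This is the same kind of exchange as the measured step, a change of ring substituents on that aryl group, with the shared core untouched. No step beyond the scatter is expected in this assay: the reading of compound 4 is expected near that of compound 3, because a number 5.8 percentage points higher from compound 2 to compound 3 (within the scatter) showed no movement for a comparable swap. Compound 4 is estimated at 0%, from -15% to 12%, a step of a number 1 percentage points lower from compound 3 to compound 4 (within the scatter).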

Compound 4, a percentage reported as inhibition, at one concentration (the size of the read-out at that concentration, not a potency): 12.3%
Compound 4: middle estimate off by 12.3 percentage points, on the low side; the whole stated range lies below it.
By their numbers in this assay, from the lowest: compound 1; then compounds 2 and 3 (each within the scatter of the next); then compound 4.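

In this assay, this position is not silent after all: with 2,4-difluorophenyl on a saturated chain carbon bound to an aromatic nitrogen, the read-out shows a number 11.3 percentage points higher from compound 3 to compound 4 (beyond the scatter) and a number 17.1 percentage points higher from compound 2 to compound 4 (beyond the scatter). The earlier swap from 2-chlorophenyl to 4-methoxyphenyl stayed within the scatter, so the aryl group at this position can change the reading, though not with every exchange, and both steps beyond the scatter are modest and rest on compound 4 alone. No supporting evidence is available to explain why this aryl group differs from the other two.

The compounds shown leave open whether the two fluorines are both needed, as no aryl group here carries a single fluorine. Also open, going by these compounds, is how the reading would respond to an aryl group bearing a carboxylic acid or an amine at this position.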